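A thiophene ring in place of the hydroxymethyl group

A few compounds are considered here, and "the series" means these few. Any claim that something is new, unique, unknown or untested is made for them only; others in the source may bear on it.

Three compounds built on one shared sugar-bearing core have been examined in a functional assay on L1210 cells (Mus musculus); a lower number here means a stronger inhibitor, a higher number a weaker inhibitor. Compound 1 `CCCCCCCCc1cn([C@@H]2O[C@H](CO)[C@@H](O)[C@H]2O)nn1` gives 56000 nM. Compound 3 `COc1ccc(-c2cn([C@@H]3O[C@H](CO)[C@@H](O)[C@H]3O)nn2)cc1` gives 152000 nM. Compound 2 `OCc1cn([C@@H]2O[C@H](CO)[C@@H](O)[C@H]2O)nn1` reaches only the limit of the assay, > 200000 nM, so no number is known for it. Going by the values given here, the one measured step, an at least 3.5-fold higher number from compound 1 to compound 2 (0.55 log units; beyond the scatter), runs up to the limit of > 200000 nM in this assay, at which 1 of the 3 values shown sits. Compound 4 `OC[C@H]1O[C@@H](n2cc(-c3ccsc3)nn2)[C@H](O)[C@@H]1O` differs from compound 2 by thiophen-3-yl in place of hydroxymethyl on an aromatic carbon. Among the compounds with values here, no measured step covers this change. Compound 3, which also carries an aromatic ring on the core, stands at 152000 nM. Compound 2 sits at its limit. The step from compound 2 to compound 4 is therefore expected to be an at least 1.3-fold lower number from compound 2 to compound 4 (0.12 log units; that floor lies within the scatter). For compound 4 the expected value is 150000 nM, within 50000 nM to 400000 nM.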

Compound 4, half-maximal inhibitory concentration: 182000 nM
Compound 4: the middle estimate sits 1.2-fold (0.08 log units) below what was measured; the range from low to high includes it.
By their numbers in this assay, from the lowest: compound 1; then compounds 3 and 4 (each within the scatter of the next). At a limit, above all of these: compound 2.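

With thiophen-3-yl on this aromatic carbon, in this assay compound 4 gives a measured number, which compound 2 with hydroxymethyl did not. The change reads as an at least 1.0-fold lower number from compound 2 to compound 4 (0.04 log units; that floor lies within the scatter) and so gives only a floor for the step. As far as these compounds go, its true size stays unknown because compound 2 stands at a limit: the limit of > 200000 nM in this assay, at which 1 of the 4 values shown sits.

The compounds shown leave open how an amine or a carboxylic acid on this same aromatic carbon would read in this assay and how they would compare with thiophen-3-yl.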